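Ring nitrogen substituent and minimum effective dose

This account rests on a few compounds, and the source may have more. Where it says the series, first, only, none or still open, it means among the compounds named here.

Measured compounds:
- compound 1 `O=C1NC2(CC2c2ccc3cccc(OCc4ccccc4)c3n2)C(=O)N1c1cc(Cl)cc(Cl)c1`; in a functional assay on the whole organism (strain Kunming) with Mus musculus as the target, with a stated time of 0.5 h (a higher number here means that more compound is needed for the effect, a lower number that less compound is needed), compound 1 gives 300 mg/kg
- compound 2 `O=C1NC(=O)C2(CC2c2ccc3cccc(OCc4ccccc4)c3n2)N1`; in this assay compound 2 gives 300 mg/kg
- compound 3 `CCC(CO)N1C(=O)NC2(CC2c2ccc3cccc(OCc4ccccc4)c3n2)C1=O`; in this assay compound 3 gives 100 mg/kg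

Compound 3 holds the lowest number of the three. The steps leading to it are a 3.0-fold lower number from compound 1 to compound 3 (0.48 log units; beyond the scatter) and a 3.0-fold lower number from compound 2 to compound 3 (0.48 log units; beyond the scatter), both beyond the scatter, whereas no change at the digits printed from compound 1 to compound 2 (within the scatter). Compound 4 `O=C1NC2(CC2c2ccc3cccc(OCc4ccccc4)c3n2)C(=O)N1c1ccc([N+](=O)[O-])cc1` differs from compound 3 as follows: 4-nitrophenyl in place of 1-(hydroxymethyl)propyl on an amide-type nitrogen in a ring.

For the measured compounds named here, the steps that bear on this change are the ones altering the same ring nitrogen. Compound 1, with 3,5-dichlorophenyl there, and compound 2, with hydrogen there, share the same number within the scatter; only compound 3, with 1-(hydroxymethyl)propyl, departs from it. Putting another substituted phenyl, 4-nitrophenyl, in that place is expected to undo that departure. For compound 4 the expected step is a 3.0-fold higher number from compound 3 to compound 4 (0.48 log units; beyond the scatter) in this assay. Compound 4 is estimated at 300 mg/kg, with a range from 100 mg/kg to 1000 mg/kg.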

Compound 4, minimum effective dose: 300 mg/kg
Estimate against measurement, compound 4: no gap at the digits printed; measured number inside the range.
By their numbers in this assay, from the lowest: compound 3; then compounds 1, 2 and 4 (each within the scatter of the next).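

In this assay, no change at the digits printed from compound 1 to compound 4 (within the scatter) shows that a second substituted phenyl on the ring nitrogen cannot be told apart from 3,5-dichlorophenyl, and no change at the digits printed from compound 2 to compound 4 (within the scatter) shows that neither phenyl group separates from hydrogen at this position. The exchange of 1-(hydroxymethyl)propyl for 4-nitrophenyl gives a 3.0-fold higher number from compound 3 to compound 4 (0.48 log units; beyond the scatter), so among these four compounds only compound 3 stands apart, and the two phenyl groups, despite their different substituents, do not. Nothing available explains why this one group departs from the others.

As far as these compounds go, whether the lower number of compound 3 goes with the hydroxyl or with the carbon chain that carries it remains open. A 1-methylpropyl group without the hydroxyl, or an amine in place of the hydroxyl, would separate these two readings.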